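Bromo to Chloro on a Weakly Cytotoxic Core

This account rests on a few compounds, and the source may have more. Where it says the series, first, only, none or still open, it means among the compounds named here.

Compound 1 `Cc1ccc2nc(/N=C3\C(=O)N(CN(c4ccccc4)c4ccccc4)c4ccccc43)sc2c1`: 34100 nM
Compound 2 `CN(C)CN1C(=O)C(=O)c2c(Br)cccc21`: 93700 nM

In a functional assay on MDA-MB-231 cells (Homo sapiens) for cytotoxicity, read by sulforhodamine B assay, with a stated time of 48 h (on this read-out higher numbers stand for weaker inhibition of growth and lower numbers for stronger inhibition of growth), compound 2 gives 93700 nM, the highest of the two numbers measured; the nearest is compound 1 with 34100 nM, a gap beyond the scatter. Compound 3 `CN(C)CN1C(=O)C(=O)c2c(Cl)cccc21` differs from compound 2 in one place: chloro in place of bromo on an aromatic carbon. Both compounds share the same core, and nothing measured here shows how this change acts, so the step is expected to be small, in no clear direction and not beyond the scatter. Compound 3 is therefore estimated at 100000 nM, between 45000 nM and 220000 nM, a step of a 1.1-fold higher number from compound 2 to compound 3 (0.03 log units; within the scatter).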

Compound 3, concentration for 50% growth inhibition: 138000 nM
Beside the measured number, compound 3's estimate is 1.4-fold (0.14 log units) below it; measured number inside the range.
By their numbers in this assay, from the lowest: compound 1; then compounds 2 and 3 (each within the scatter of the next).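

In this assay, chloro in place of bromo on an aromatic carbon gives a 1.5-fold higher number from compound 2 to compound 3 (0.17 log units; within the scatter), so the two halogens cannot be told apart at this position on this read-out. The exchange of one for the other thus stays within the scatter on this core. No available evidence bears on how this change acts. Going by these compounds, whether an amine, a methoxy group or a carboxylic acid on this aromatic carbon would give a step beyond the scatter stays open. So does the effect of a longer chain in place of the dimethylaminomethyl group of compound 3.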